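Replacing benzyloxy with cyclohexyl on the core's aromatic ring

The compounds below may be only part of what the source reports. "The series", "measured", "known", "first", "only" and "open" are said of these compounds alone.

Compound 1, `CC(C(=O)NCc1ccc(C(F)(F)F)cc1N1CCN(C2CCCCC2)CC1)c1ccc(NS(C)(=O)=O)c(F)c1`: 13.8 nM
Compound 2, `Cc1ccc(N2CCN(c3cc(C(F)(F)F)ccc3CNC(=O)C(C)c3ccc(NS(C)(=O)=O)c(F)c3)CC2)cc1`: 0.7 nM
Compound 3, `CC(C(=O)NCc1ccc(C(F)(F)F)cc1OCc1ccccc1)c1ccc(NS(C)(=O)=O)c(F)c1`: 0.9 nM

In an assay on CHO cells for antagonist activity at transient receptor potential cation channel subfamily V member 1 (Homo sapiens), read by FLIPR (on this read-out higher numbers stand for weaker inhibition and lower numbers for stronger inhibition), compound 3 gives 0.9 nM and stands second highest of the three numbers; its nearest neighbour is compound 2, within the scatter, while compound 1 lies well apart, beyond the scatter. Compound 4, `CC(C(=O)NCc1ccc(C(F)(F)F)cc1C1CCCCC1)c1ccc(NS(C)(=O)=O)c(F)c1`, has not yet been measured. It differs from compound 3 in one place: cyclohexyl in place of benzyloxy on an aromatic carbon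

Going by the values given here, two measured steps touch this region of the core. The step of a 15-fold lower number from compound 1 to compound 3 (1.19 log units; beyond the scatter) shows that benzyloxy at this carbon goes with a much lower number than 4-cyclohexylpiperazin-1-yl. The step of a 20-fold lower number from compound 1 to compound 2 (1.29 log units; beyond the scatter) shows, on the piperazine nitrogen, that 4-methylphenyl gives a much lower number than cyclohexyl. Among the compounds with values here, neither step is the same change as the one from compound 3 to compound 4, but both put cyclohexyl on the side of higher numbers and an aromatic ring on the side of lower numbers. A moderate rise in this assay is therefore expected, a 3.3-fold higher number from compound 3 to compound 4 (0.52 log units; beyond the scatter), though with wide uncertainty since no direct cyclohexyl-on-carbon comparison exists. Compound 4 is estimated at 3 nM, within 0.7 nM to 15 nM.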

Compound 4, inhibition constant: 0.6 nM
Compound 4: the middle estimate sits 5.0-fold (0.70 log units) above what was measured, and the stated range ends above it.
By their numbers in this assay, from the lowest: compounds 4, 2 and 3 (each within the scatter of the next); then compound 1.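

In this assay, putting cyclohexyl in place of benzyloxy on this aromatic carbon gives a 1.5-fold lower number from compound 3 to compound 4 (0.18 log units; within the scatter) and so leaves the number unmoved within the scatter: at this position, neither the aromatic ring nor the oxygen of benzyloxy is needed for a value of this size, and a non-aromatic carbon ring with fewer heavy atoms does as well. The earlier compounds had shown cyclohexyl only on the piperazine nitrogen, where it went with the highest number, whereas a 23-fold lower number from compound 1 to compound 4 (1.36 log units; beyond the scatter) shows that cyclohexyl attached directly to the aromatic carbon does not carry that penalty, so a cyclohexyl group cannot be read as unfavourable in itself across these compounds. Nothing available explains why benzyloxy and cyclohexyl behave alike here.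

Going by these compounds, whether a phenyl ring set directly on this carbon, a methoxy group or a plain hydrogen would keep such numbers stays open, and with it how much of a group this position needs at all. Also open, on these data alone, is whether cyclohexyl would behave the same way with a nitrile in place of the trifluoromethyl group.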